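Taking the amino group off compound 1

A few compounds are considered here, and "the series" means these few. Any claim that something is new, unique, unknown or untested is made for them only; others in the source may bear on it.

Measured in an ADME assay on a cell-free system (plasma, Rattus norvegicus) for metabolic stability, read by HPLC; on this read-out higher numbers stand for a longer-lived compound and lower numbers for a shorter-lived compound:
- compound 1 `CC[C@H](C)[C@H](NC(=O)[C@H]1Cc2ccc(O)c(c2)CC=CCNCCCC[C@H](N)C(=O)N[C@@H](CCCCN)C(=O)N2CCC[C@H]2C(=O)N1)C(=O)N[C@@H](CC(C)C)C(=O)O`: 0.317 h
- compound 2 `CC[C@H](C)[C@H](NC(=O)[C@H]1Cc2ccc(O)c(c2)CC=CCN(S(=O)(=O)c2ccccc2[N+](=O)[O-])CCCC[C@H](N)C(=O)N[C@@H](CCCCN)C(=O)N2CCC[C@H]2C(=O)N1)C(=O)N[C@@H](CC(C)C)C(=O)O`: 1.4 h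

Of these two numbers, the lower belongs to compound 1. Compound 3 `CC[C@H](C)[C@H](NC(=O)[C@H]1Cc2ccc(O)c(c2)CC=CCNCCCCCC(=O)N[C@@H](CCCCN)C(=O)N2CCC[C@H]2C(=O)N1)C(=O)N[C@@H](CC(C)C)C(=O)O` keeps the core of compound 1 with one change: hydrogen in place of amino on a saturated ring carbon. Going by the values given here, only one measured step bears on this, and only loosely. It puts (2-nitrophenyl)sulfonyl in place of hydrogen on a ring nitrogen, which is a different change at a different atom. Among the compounds with values here, no measured compound shows what losing the amino group does. Taking a 4.4-fold higher number from compound 1 to compound 2 (0.65 log units; beyond the scatter) as a rough scale, a modest rise in this assay is expected, though a fall cannot be ruled out. The estimated step is a 2.2-fold higher number from compound 1 to compound 3 (0.34 log units; beyond the scatter). For compound 3 the expected half-life is 0.7 h, with an estimated range from 0.25 h to 2.5 h.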

Compound 3, half-life: 24 h
Compound 3: middle estimate off by 34-fold (1.54 log units), on the low side; measured number above the stated range.
By their numbers in this assay, from the lowest: compound 1; then compound 2; then compound 3.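

In this assay, taking the amino group off the saturated ring carbon gives a 76-fold higher number from compound 1 to compound 3 (1.88 log units; beyond the scatter). Going by these compounds alone, this large step comes from the loss of one heavy atom, with the rest of the core of compound 1 unchanged, so the half-life in this test is far more sensitive to this carbon than the only earlier step, a modest one at a different atom, could show. Nothing measured here speaks to what lies behind the rise.

On these data alone, it remains open whether any replacement of the amino group at this carbon would do the same, or only bare hydrogen; a hydroxyl, a methyl or an acetylated amine there would begin to tell. Also open, as far as these compounds go, is how (2-nitrophenyl)sulfonyl on the ring nitrogen would act once the amino group is gone.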